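Compound 2 to compound 3: pyridin-4-yl replaced by 3-fluorophenyl

The compounds below may be only part of what the source reports. "The series", "measured", "known", "first", "only" and "open" are said of these compounds alone.

For the measured compounds named here, in a functional assay on a cell-free system (plasma, Oryctolagus cuniculus) for inhibition, with stated times of 5 min, 1 min and 6 min (a higher number here means a weaker inhibitor, a lower number a stronger inhibitor), compound 1 `CCOC(=O)c1c(C)nc(-c2cccc(C#N)c2)n1C` gives 22100 nM and compound 2 `CCOC(=O)c1c(C)nc(-c2cccc(C#N)c2)n1OCc1ccncc1` gives 6200 nM as the lower of the two numbers so far. Next in the series is compound 3 `CCOC(=O)c1c(C)nc(-c2cccc(C#N)c2)n1OCc1cccc(F)c1` with one structural change from compound 2 (3-fluorophenyl in place of pyridin-4-yl on a saturated chain carbon bound to an oxygen on an aromatic ring) and the rest of the structure unchanged. Going by the values given here, only one measured step bears on this change: a 3.6-fold lower number from compound 1 to compound 2 (0.55 log units; beyond the scatter) with (pyridin-4-yl)methoxy in place of methyl on an aromatic nitrogen. Among the compounds with values here, that step exchanged the whole substituent, so no measured pair isolates the aromatic ring at its end, and the data give no direction for the swap to 3-fluorophenyl. Within the data shown here, the expectation rests on a 3.6-fold lower number from compound 1 to compound 2 (0.55 log units; beyond the scatter) as the only measured change at this place, and a smaller move is expected here, since the chain and its oxygen stay. The expected step is a 1.1-fold lower number from compound 2 to compound 3 (0.05 log units; within the scatter) in this assay and no shift beyond the scatter is anticipated. For compound 3 the estimated value is 5500 nM with an expected range from 1800 nM to 16000 nM as the working figure.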

Compound 3, half-maximal inhibitory concentration: 22400 nM
Beside the measured number, compound 3's estimate is 4.1-fold (0.61 log units) below it; the measured number lies above the stated range.
By their numbers in this assay, from the lowest: compound 2; then compounds 1 and 3 (each within the scatter of the next).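

For the compounds shown here, with the chain and its oxygen held constant, the ring at the end of the substituent alone moves the number in this assay (a 3.6-fold higher number from compound 2 to compound 3 (0.56 log units; beyond the scatter)), showing what no earlier pair could: the identity of that ring matters at this position. On the aromatic nitrogen, (3-fluorobenzyl)oxy and methyl stand level (a 1.0-fold higher number from compound 1 to compound 3 (0.01 log units; within the scatter)), so the chain and oxygen do not by themselves carry the lower number of compound 2, and among these three compounds that lower number appears only with pyridin-4-yl. No measurement offers an explanation for the difference between the two ring ends.

The change from compound 2 to compound 3 removes the ring nitrogen and adds a fluorine in one step, leaving open which of the two accounts for the shift, and a plain phenyl ring at the end of the chain would separate them. Also open, going by these compounds, is whether pyridin-4-yl keeps its standing on a longer chain, or whether an amine on the same chain matches it.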